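Adding a second fluoro to compound 3

The source may report more compounds than this note shows. Statements on the series, on what has been measured and on what is new or still open speak of the compounds shown alone.

Compound 3 (`Nc1nccn2c(Cc3cccc(F)c3)nnc12`) stands only at a limit in a functional assay on the whole organism with Rattus norvegicus as the target, in the maximal electroshock model; on this read-out higher numbers stand for an effect only at larger amounts of compound and lower numbers for an effect already at smaller amounts (> 25 mg/kg). In this assay compound 1 (`Nc1nccn2c(Cc3ccccc3F)nnc12`) gives a number (9 mg/kg), and compound 2 (`CNc1nccn2c(Cc3cccc(F)c3)nnc12`) gives one too (4 mg/kg). Compound 4 (`Nc1nccn2c(Cc3cc(F)ccc3F)nnc12`) differs from compound 3 by fluoro in place of hydrogen on an aromatic carbon, ortho to a large group (fluoro in place of hydrogen on an aromatic carbon). Within the data shown here, the only measured step (an at least 6.2-fold higher number from compound 2 to compound 3 (0.79 log units; beyond the scatter)) lies on the nitrogen, so it bears on this change only indirectly, showing that one small change can go beyond the scatter. The closest guide is compound 1 (9 mg/kg), whose fluoro is also ortho to a large group. A lower number is therefore expected, an estimated step (an at least 1.7-fold lower number from compound 3 to compound 4 (0.25 log units; that floor lies within the scatter)) in this assay that remains uncertain. Compound 4 is estimated at 14 mg/kg, within a range from 6 mg/kg to 35 mg/kg.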

Compound 4, dose for half-maximal effect: 7 mg/kg
Estimate against measurement, compound 4: 2.0-fold (0.30 log units) above; measured number inside the range.
By their numbers in this assay, from the lowest: compounds 2, 4 and 1 (each within the scatter of the next, the first and the last beyond it). At a limit, above all of these: compound 3.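

In this assay, fluoro in place of hydrogen ortho to a large group moves the number beyond the scatter (an at least 3.5-fold lower number from compound 3 to compound 4 (0.55 log units; beyond the scatter)), the first such shift seen from a change on this aromatic ring. Compound 1, which already has a fluoro there, and compound 4 stand within the scatter of each other (a 1.3-fold lower number from compound 1 to compound 4 (0.11 log units; within the scatter)), so the fluoro para to it adds nothing readable.

Going by these compounds, the full size of the first step stays open because compound 3 stands only at a limit: the limit of > 25 mg/kg in this assay, at which 1 of the 4 values shown sits. On these data alone, whether chloro, methyl or methoxy at this position would serve like fluoro also stays open.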